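Notes on a low-stability compound and its methoxy analogue

The source may hold more compounds than are shown below. What is called first, only, known or untested is meant among the compounds shown, and "the series" means these compounds.

In an ADME assay on cells (Hepatocyte, Homo sapiens) for metabolic stability, with a stated time of 30 min (on this read-out higher numbers stand for a more stable compound and lower numbers for a less stable compound), compound 1 (`CS(=O)(=O)NC1CCC(CN2CCN(c3cc(=O)c4cc(C(F)(F)F)cc([N+](=O)[O-])c4s3)CC2)CC1`) gives 105%, while compound 2 (`O=C(OC1CCC(CN2CCN(c3cc(=O)c4cc(C(F)(F)F)cc([N+](=O)[O-])c4s3)CC2)CC1)c1ccc(C(F)(F)F)cc1`) gives 5.2%. Compound 2 therefore holds the lower of the two numbers, and its gap to compound 1 lies beyond the scatter.

The next compound to be read is compound 3 (`COc1ccc(C(=O)OC2CCC(CN3CCN(c4cc(=O)c5cc(C(F)(F)F)cc([N+](=O)[O-])c5s4)CC3)CC2)cc1`), which differs from compound 2 in one place: methoxy in place of trifluoromethyl on an aromatic carbon. This is methoxy in place of trifluoromethyl on an aromatic carbon, para to a large group. Among the compounds with values here, no measured pair yet differs in one place only, so the data give no direct reading of what such a swap does in this assay.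

The expectation is accordingly modest. Compound 3 keeps everything in compound 2, which stands at 5.2%, apart from this one group, so it should stay near the low end of the numbers seen so far. The estimated move is a number 4.8 percentage points higher from compound 2 to compound 3 (within the scatter), a small rise expected to stay within the scatter. For compound 3 the expected value is 10%, with an estimated range from 2% to 30%.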

Compound 3, percent of the compound remaining: 12.2%
Beside the measured number, compound 3's estimate is 2.2 percentage points below it, and the stated range covers the measured number.
By their numbers in this assay, from the lowest: compounds 2 and 3 (each within the scatter of the next); then compound 1.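

Methoxy in place of trifluoromethyl on an aromatic carbon, para to a large group, now has a direct reading in this assay: a number 7 percentage points higher from compound 2 to compound 3 (within the scatter), so this single swap does not separate the two compounds on this read-out. The large gap remains with the other change, ((4-methoxyphenyl)carbonyl)oxy in place of methanesulfonamido on a saturated ring carbon, which reads as a number 92.8 percentage points lower from compound 1 to compound 3 (beyond the scatter), and on these compounds the number therefore follows the group on the saturated ring carbon far more than the swap on the aromatic ring. Nothing at hand gives a reason for either step.

The compounds shown leave open whether a different group on the same aromatic carbon, such as an amine or a carboxylic acid, would give a step beyond the scatter. They also leave open whether an amide in place of the ester on the saturated ring carbon would read closer to compound 1 or closer to compound 3.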